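The source may report more compounds than this note shows. Statements on the series, on what has been measured and on what is new or still open speak of the compounds shown alone.

Compound 1 `Nc1ncnc2c1c(-c1ccc(Oc3ccccc3)cc1)cn2C[C@H]1CCCN1C[C@@H](O)CO`: 13500 nM
Compound 2 `Nc1ncnc2c1c(-c1cc3ccccc3o1)cn2[C@H]1CCN(C[C@H]2CO2)C1`: 1650 nM

In a functional assay on Ramos cells (Homo sapiens) for antiproliferative activity (a higher number here means a weaker inhibitor, a lower number a stronger inhibitor), compound 1 gives the higher of these two numbers, and compound 2 sits well below it, beyond the scatter. Compound 3 `Nc1ncnc2c1c(-c1ccc(Oc3ccccc3)cc1)cn2[C@H]1CCN(C[C@@H]2CO2)C1` differs from compound 1 in one place: 1-((oxiran-2-yl)methyl)pyrrolidin-3-yl in place of (1-(2,3-dihydroxypropyl)pyrrolidin-2-yl)methyl on an aromatic nitrogen. Among the measured compounds shown here, no pair of measured compounds differs in a single place, so no measured step guides this change; the group that enters is, however, the one compound 2 carries. The step of a 5.4-fold lower number from compound 1 to compound 3 (0.73 log units; beyond the scatter) is expected to bring a clearly lower number. Compound 3 is expected to give about 2500 nM in this assay, within 700 nM to 9000 nM.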

Compound 3, half-maximal inhibitory concentration: 6710 nM
Beside the measured number, compound 3's estimate is 2.7-fold (0.43 log units) below it, within the range that was stated.
By their numbers in this assay, from the lowest: compound 2; then compounds 3 and 1 (each within the scatter of the next).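

Putting 1-((oxiran-2-yl)methyl)pyrrolidin-3-yl in place of (1-(2,3-dihydroxypropyl)pyrrolidin-2-yl)methyl on the aromatic nitrogen gives, in this assay, a 2.0-fold lower number from compound 1 to compound 3 (0.30 log units; within the scatter). On this core, then, the two groups cannot be told apart in this assay, although they differ in ring content and in hydrogen-bond donors. No measurement at hand offers a reason for this result. Still open, going by these compounds, is whether another group on this nitrogen, such as an acrylamide or a simple amine, would shift the number beyond the scatter, and whether the three-membered ring itself matters at all.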